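The source may hold more compounds than are shown below. What is called first, only, known or untested is meant among the compounds shown, and "the series" means these compounds.

Compound 2 `CC(c1ccc(-c2ccccc2)c(F)c1)c1nnc2n1N=C(c1ccc(Br)cc1)CS2` gives 7000 nM in a functional assay on SNU-475 cells (Homo sapiens) for inhibition, read by sulforhodamine B assay, with a stated time of 72 h; a lower number here means a stronger inhibitor, a higher number a weaker inhibitor. For the measured compounds named here, of the two measured numbers this is the highest, yet its only neighbour, compound 1 `COc1ccc(C2=Nn3c(nnc3C(C)c3ccc(-c4ccccc4)c(F)c3)SC2)cc1`, gives 6700 nM in this assay, and the step of a 1.0-fold higher number from compound 1 to compound 2 (0.02 log units; within the scatter) lies within the scatter, so the two compounds cannot be told apart. Compound 3 `CC(c1ccc(-c2ccccc2)c(F)c1)c1nnc2n1N=C(c1ccc([N+](=O)[O-])cc1)CS2` has not yet been measured. It differs from compound 2 by nitro in place of bromo on an aromatic carbon; cut one bond further out, the change reads 4-bromophenyl to 4-nitrophenyl. Going by the values given here, the single measured step in this set, the exchange of one substituent on that same aromatic carbon, left the number within the scatter, and no step involving a nitro group has been measured at all. On that thin basis, compound 3 is expected to show no change at the digits printed from compound 2 to compound 3 (within the scatter), a step beyond the scatter in neither direction. The estimate for compound 3 in this assay is 7000 nM, with a range from 3000 nM to 16000 nM.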

Compound 3, half-maximal inhibitory concentration: 7100 nM
Estimate against measurement, compound 3: 1.0-fold (0.01 log units) below; low and high end bracket the measured number.
By their numbers in this assay, from the lowest: compounds 1, 2 and 3 (each within the scatter of the next).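

With nitro on this aromatic carbon, para to a large group, this assay gives a 1.0-fold higher number from compound 2 to compound 3 (0.01 log units; within the scatter), and against methoxy at the same place it gives a 1.1-fold higher number from compound 1 to compound 3 (0.03 log units; within the scatter). The position has now taken a third group, one with 3 heavy atoms and 2 hydrogen-bond acceptors where bromo has 1 heavy atom and no acceptor, and compound 1, compound 2 and compound 3 still cannot be told apart. Nothing at hand offers a reason for this flat reading.

Going by these compounds, whether an amine or a carboxylic acid on this same carbon would give a number that stands apart remains open. So does the question of whether any group here can move the number beyond the scatter in either direction.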